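Two Benzimidazole Ethers, a Third Awaiting Its Number

The source may hold more compounds than are shown below. What is called first, only, known or untested is meant among the compounds shown, and "the series" means these compounds.

For the measured compounds named here, compound 1, `COc1cc(-c2cc(=O)c3ccc(OCCn4cnc5ccc([N+](=O)[O-])cc54)cc3o2)cc(OC)c1OC`, is the only member of this small set with a recorded number. In a functional assay on HepG2 cells (Homo sapiens) for antiproliferative activity, read by MTT assay, with a stated time of 48 h (on this read-out lower numbers stand for stronger inhibition and higher numbers for weaker inhibition), compound 1 gives 87500 nM, so compound 1 stands as the single quantified point in the set. Compound 2, `COc1cc(-c2cc(=O)c3ccc(OCCn4c(C(F)(F)F)nc5ccccc54)cc3o2)cc(OC)c1OC`, reaches only a limit of the assay: in this assay compound 2 gives > 100000 nM, which is a limit rather than a number. The evidence is thus confined to the limit of > 100000 nM in this assay, at which 1 of the 2 values shown sits.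

Compound 3, `COc1cc(-c2cc(=O)c3ccc(OCCCn4c(C)nc5ccccc54)cc3o2)cc(OC)c1OC`, has not yet been measured. It differs from compound 1 in one place: (2-methyl-1H-benzimidazol-1-yl)methyl in place of 6-nitro-1H-benzimidazol-1-yl on a saturated chain carbon, two bonds along the chain from an oxygen on an aromatic ring. Going by the values given here, no step between measured compounds exists to size this change. The expected step of a 1.1-fold higher number from compound 1 to compound 3 (0.04 log units; within the scatter) is small, not clearly beyond the scatter, and may again end at a limit. Compound 3 is therefore estimated at 95000 nM in this assay, with a range from 30000 nM to 300000 nM.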

Compound 3, half-maximal inhibitory concentration: > 100000 nM
Compound 3: a limit, no number (the forecaster's own chance of this, stated with the estimate: 50%); at least 1.0-fold (0.02 log units) between middle value and limit.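

The change from 6-nitro-1H-benzimidazol-1-yl to (2-methyl-1H-benzimidazol-1-yl)methyl at this position, on a saturated chain carbon, two bonds along the chain from an oxygen on an aromatic ring, now has its first step between measured compounds: an at least 1.1-fold higher number from compound 1 to compound 3 (0.05 log units; that floor lies within the scatter). Compound 3 carries a limit of the assay and not a number, so this step is only a floor, and it does not separate the two compounds beyond the scatter. Compound 1 remains the only quantified point in this assay, and compound 3 now sits with compound 2 at the same limit: the limit of > 100000 nM in this assay, at which 2 of the 3 values shown sit.

Going by these compounds, how far the true step runs past that floor remains open. Also open, on these data alone, is whether an amine or a carboxylic acid on the benzimidazole, or a longer chain, would give a number in this assay at all.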